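Swapping a Branched Chain for Allyl

The compounds below may be only part of what the source reports. "The series", "measured", "known", "first", "only" and "open" are said of these compounds alone.

Compound 1 `C=CCOc1ccc(-c2ccc(OC)cc2)cc1CC=C` gives > 100000 nM (a limit)
Compound 2 `C=CC(C)(C)c1cc(-c2ccc(OC)cc2)ccc1O` gives > 100000 nM (a limit)

In a functional assay on Lewis lung carcinoma cells (Mus musculus) for antiproliferative activity, read by MTT assay, with a stated time of 24 h (on this read-out higher numbers stand for weaker inhibition and lower numbers for stronger inhibition), compound 2 gives > 100000 nM, which is a limit of the assay and not a number. Compound 1 gives > 100000 nM, which is also a limit. Both measured compounds therefore stand at the limit of > 100000 nM in this assay, at which 2 of the 2 values shown sit, and neither offers a number to build on.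

Compound 3 `C=CCc1cc(-c2ccc(OC)cc2)ccc1O` has not yet been measured. It carries allyl in place of 1,1-dimethylprop-2-en-1-yl on an aromatic carbon, ortho to a hydroxy group: allyl in place of 1,1-dimethylprop-2-en-1-yl on an aromatic carbon.

Among the measured compounds shown here, no measured step covers this change, so the expectation in this assay is tentative: a modest shift toward stronger inhibition, with a real chance that compound 3 also stays at a limit. The expected step of an at least 1.4-fold lower number from compound 2 to compound 3 (0.15 log units; that floor lies within the scatter) is small. For compound 3 the estimated value is 70000 nM, with an expected range from 25000 nM to 200000 nM.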

Compound 3, half-maximal inhibitory concentration: > 100000 nM
Compound 3 gave a limit, no number (the forecaster's own chance of this, stated with the estimate: 50%); middle value at least 1.4-fold (0.15 log units) away from the limit.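

In this assay compound 3 also gives a limit and not a number, so the steps to it from compound 2 and from compound 1 cannot be read: the limit of > 100000 nM in this assay, at which 3 of the 3 values shown sit. The compounds shown leave open which change to the shared core, if any, would bring a measurable value.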